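Compound 1 and its unmeasured 2-allylphenyl counterpart

The compounds below may be only part of what the source reports. "The series", "measured", "known", "first", "only" and "open" are said of these compounds alone.

Measured in a functional assay on ileum (Cavia porcellus) for antagonist activity, with a stated time of 30 s; a higher number here means a weaker inhibitor, a lower number a stronger inhibitor:
- compound 1 `CC(=O)c1ccc(OCC(O)COc2ccc3c(=O)cc(C(=O)O)oc3c2)cc1O`: 28 ug/mL
- compound 2 `C=CCc1c(OCC(O)COc2ccc(C(C)=O)c(O)c2)ccc2c(=O)cc(C(=O)O)oc12`: 3.3 ug/mL

Of these two measured compounds, compound 1 has the higher number and is therefore the weaker inhibitor in this assay. Compound 3 `C=CCc1ccccc1OCC(O)COc1ccc2c(=O)cc(C(=O)O)oc2c1` has not yet been measured. It differs from compound 1 by having 2-allylphenyl in place of 4-acetyl-3-hydroxyphenyl on an oxygen on a saturated carbon.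

Among the compounds with values here, only one measured step bears on this change: allyl in place of hydrogen on an aromatic carbon, which gave an 8.5-fold lower number from compound 1 to compound 2 (0.93 log units; beyond the scatter). It is a loose guide. Compound 2 keeps the 4-acetyl-3-hydroxyphenyl group that compound 3 gives up, and no measurement shows what that loss does alone. Only part of the measured step is therefore expected to carry over, in the same direction. The expected change is a 2.3-fold lower number from compound 1 to compound 3 (0.37 log units; beyond the scatter). For compound 3 the estimated value is 12 ug/mL, with an expected range of 3.5 ug/mL to 40 ug/mL.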

Compound 3, half-maximal inhibitory concentration: 1.8 ug/mL
For compound 3 the middle estimate is 6.7-fold (0.82 log units) above the measured one; measured number below the stated range.
By their numbers in this assay, from the lowest: compounds 3 and 2 (each within the scatter of the next); then compound 1.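

In this assay, replacing 4-acetyl-3-hydroxyphenyl with 2-allylphenyl on the oxygen on a saturated carbon gave a 16-fold lower number from compound 1 to compound 3 (1.19 log units; beyond the scatter) and counts as a large step. This shows what compound 2 could not: the 4-acetyl-3-hydroxyphenyl group is not needed for inhibition in this assay, and giving it up at this position makes compound 3 the stronger inhibitor of the pair. The entering group carries no hydrogen-bond donors or acceptors, whereas the leaving group carries both, so those features of the leaving group are not required for activity here, and no available evidence accounts for the gain.

The compounds shown do not separate the contribution of the allyl group from that of the aromatic ring in 2-allylphenyl, so it remains open how an unsubstituted phenyl or a 2-propylphenyl group would behave at this position. Also open, on these data alone, are whether an ethyl ester could stand in for the carboxylic acid on the shared core and what an allyl group on the core of compound 3 would add.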